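Chloro for fluoro on the aromatic carbon: compound 2 to 3

The compounds below may be only part of what the source reports. "The series", "measured", "known", "first", "only" and "open" are said of these compounds alone.

Measured so far:
Compound 1 `C(=C1\CCN=C1c1cccnc1)\c1ccccc1`: 41.3%
Compound 2 `Fc1ccc(/C=C2\CCN=C2c2cccnc2)cc1`: 22.3%

In an assay for displacement of a labelled ligand from Nicotinic acetylcholine receptor alpha8 subunit (Periplaneta americana), read by scintillation counting, with a stated time of 2 h, at 24 degrees C, tested at 10 uM (on this read-out lower numbers stand for less inhibition and higher numbers for more inhibition at the one concentration tested (going by the name of the read-out)), compound 1 gives 41.3%; compound 2 gives 22.3%. Among the compounds with values here, compound 2 stands lowest of the two numbers, and the only step known so far is the one from compound 1 to it, a number 19 percentage points lower from compound 1 to compound 2 (beyond the scatter), which is fluoro in place of hydrogen on an aromatic carbon and lies beyond the scatter.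

Compound 3 `Clc1ccc(/C=C2\CCN=C2c2cccnc2)cc1` is the next member. It differs from compound 2 by chloro in place of fluoro on an aromatic carbon. Within the data shown here, no measured step covers this change: the one step in hand exchanges hydrogen for fluoro, not fluoro for chloro, so it gives only an indirect pointer, namely that a substituent at this aromatic carbon went with a modestly lower number in this assay. With nothing more to go on, the expectation for this assay is a step of a number 1.7 percentage points higher from compound 2 to compound 3 (within the scatter), that is, no change beyond the scatter.

Compound 3 is therefore estimated at 24%, with a range from 5% to 45%.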

Compound 3, a percentage reported as inhibition, at one concentration (the size of the read-out at that concentration, not a potency): 21.5%
For compound 3 the middle estimate is 2.5 percentage points above the measured one; the measured number falls inside the stated range.
By their numbers in this assay, from the lowest: compounds 3 and 2 (each within the scatter of the next); then compound 1.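

With a number 0.8 percentage points lower from compound 2 to compound 3 (within the scatter) in this assay for chloro in place of fluoro, on the aromatic carbon para to a large group, the two halogens are not told apart at this position. The step of a number 19.8 percentage points lower from compound 1 to compound 3 (beyond the scatter) for chloro in place of hydrogen shows that the lower number seen with fluoro also comes with a second halogen, so it is not confined to fluoro in these compounds. No measured evidence accounts for the lower number with either halogen or for the lack of a separation between them.

The compounds shown carry only hydrogen, fluoro or chloro at this place, so it remains open whether a non-halogen group such as methoxy, a nitrile or an amine would go with a number as low as the halogens or return it towards that of compound 1. Also open, as far as these compounds go, is whether bromo or a longer chain here would continue to sit with the two halogens, and since each number comes from one concentration, none of these comparisons gives a potency.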